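A few compounds are considered here, and "the series" means these few. Any claim that something is new, unique, unknown or untested is made for them only; others in the source may bear on it.

Working notes on the series. In an assay on cells for displacement of a labelled ligand from adenosine receptor A1 (Homo sapiens), read by radioligand binding, with a stated time of 60 min, tested at 1 uM (on this read-out lower numbers stand for less inhibition and higher numbers for more inhibition at the one concentration tested (going by the name of the read-out)), compound 1 `CC(C)OC(=O)C1=C(C(F)(F)F)NC(=O)NC1c1ccoc1` gives 27%, the higher of the two numbers recorded so far. Among the measured compounds shown here, its nearest measured neighbour is compound 2 `CC(C)OC(=O)C1=C(C(F)(F)F)NC(=O)NC1c1ccco1`, which in this assay gives 11%; the single measured step, a number 16 percentage points lower from compound 1 to compound 2 (beyond the scatter), is a change of the furan attachment on the shared core and says nothing about the ester side of the molecule.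

Compound 3 `CCOC(=O)C1=C(C(F)(F)F)NC(=O)NC1c1ccoc1` differs from compound 1 by hydrogen in place of methyl on a saturated chain carbon bound to an oxygen next to a carbonyl group and a saturated chain carbon. For the measured compounds named here, no measured step touches this position, so there is no direct precedent, and the only recorded step is not of the same kind. Removal of a single methyl from the ester chain is a small change; a step of no more than the usual scatter is expected, a number 2 percentage points lower from compound 1 to compound 3 (within the scatter). For compound 3 in this assay the estimated value is 25%, with a range from 10% to 40%.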

Compound 3, a percentage reported as inhibition, at one concentration (the size of the read-out at that concentration, not a potency): 37%
Estimate against measurement, compound 3: 12 percentage points below, and the stated range covers the measured number.
By their numbers in this assay, from the lowest: compound 2; then compounds 1 and 3 (each within the scatter of the next).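

In this assay the ester side of the series now has its first measured step, a number 10 percentage points higher from compound 1 to compound 3 (within the scatter) for isopropyl to ethyl, read one bond further out as isopropoxycarbonyl to ethoxycarbonyl. Removing this methyl therefore leaves the read-out within the scatter, so compound 1 and compound 3 cannot be put in order, whereas the step at the furan attachment lies beyond it. Nothing available gives a reason for this result.

As far as these compounds go, whether the difference between furan-3-yl and furan-2-yl carries over from the isopropyl ester to the ethyl ester remains open. Also open, from the compounds shown here alone, is how the read-out responds at this place to a larger change, such as a longer chain like n-butyl or a carboxylic acid in place of the ester.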